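This account rests on a few compounds, and the source may have more. Where it says the series, first, only, none or still open, it means among the compounds named here.

Measured in a functional assay on A549 cells (Homo sapiens) for cytotoxicity, read by resazurin assay, with a stated time of 72 h (a lower number here means a stronger inhibitor, a higher number a weaker inhibitor), so far:
- compound 1 `Nc1c(-c2nc3ccccc3[nH]2)cc(-c2ccccc2)n1-c1ccncc1` gives 1100 nM
- compound 2 `Nc1c(-c2nc3ccccc3[nH]2)cc(-c2ccccc2)n1-c1cccc(Br)c1` gives 13500 nM

Compound 2 holds the higher of the two numbers in this assay and stands alone at that end of this small set. Compound 3 `Nc1c(-c2nc3ccccc3[nH]2)cc(-c2ccccc2)n1-c1cccc(Cl)c1` is still unmeasured and differs from compound 2 by chloro in place of bromo on an aromatic carbon in that it has chloro in place of bromo on an aromatic carbon, meta to a large group. Among the measured compounds shown here, the only measured step is a 12-fold higher number from compound 1 to compound 2 (1.09 log units; beyond the scatter) and it is large, but it exchanges the whole group on the aromatic nitrogen. For the measured compounds named here, no measured pair exchanges bromo for chloro, so a step of that size is not carried over, and none beyond the scatter is expected. The expected step is a 1.2-fold lower number from compound 2 to compound 3 (0.09 log units; within the scatter) and no larger. For compound 3 the estimated value is 11000 nM with an expected range from 5000 nM to 25000 nM in this series.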

Compound 3, half-maximal inhibitory concentration: 7000 nM
Estimate against measurement, compound 3: 1.6-fold (0.20 log units) above, and the stated range covers the measured number.
By their numbers in this assay, from the lowest: compound 1; then compounds 3 and 2 (each within the scatter of the next).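

In this assay, the exchange of bromo for chloro on the aromatic carbon, meta to a large group, gives a 1.9-fold lower number from compound 2 to compound 3 (0.29 log units; within the scatter), so the two halogens cannot be told apart at this place. The gap to the pyridin-4-yl group on the aromatic nitrogen does not rest on bromo alone: the chloro analogue also stands apart, with a 6.4-fold higher number from compound 1 to compound 3 (0.80 log units; beyond the scatter), so in these three compounds both halogenated phenyl groups carry higher numbers than pyridin-4-yl. Nothing available bears on the cause of either step.

The compounds shown leave open whether fluoro, methoxy or an amine at the same place would stay with compound 2 and compound 3 or move towards compound 1. They also leave open how an unsubstituted phenyl group on the aromatic nitrogen would compare with pyridin-4-yl.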